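A few compounds are considered here, and "the series" means these few. Any claim that something is new, unique, unknown or untested is made for them only; others in the source may bear on it.

The two measured compounds share one core and differ only in the group carried on a saturated chain carbon bound to an amide-type nitrogen. Compound 1 `COc1cc(N(Cc2ccccc2)C(=O)CSc2nc3ccccc3s2)cc(OC)c1OC` gives 54100 nM in a functional assay on PC-3 cells (Homo sapiens) for antiproliferative activity, read by MTT assay, with a stated time of 48 h; a higher number here means a weaker inhibitor, a lower number a stronger inhibitor. Compound 2 `COc1cc(CN(C(=O)CSc2nc3ccccc3s2)c2cc(OC)c(OC)c(OC)c2)cc(OC)c1OC` reaches only the limit of this assay, > 80000 nM, so for compound 2 no number is known, only a limit. The step of an at least 1.4-fold higher number from compound 1 to compound 2 (0.16 log units; that floor lies within the scatter) is therefore known only by its floor, and compound 2 sits at the limit of > 80000 nM in this assay, at which 1 of the 2 values shown sits. Compound 3 `COc1ccc(CN(C(=O)CSc2nc3ccccc3s2)c2cc(OC)c(OC)c(OC)c2)cc1N=[N+]=[N-]` alters the same place once more: 3-azido-4-methoxyphenyl in place of 3,4,5-trimethoxyphenyl on a saturated chain carbon bound to an amide-type nitrogen. Going by the values given here, the only measured step that bears on this place is the one already described, and its floor lies within the scatter, so it gives no direction for a change from one substituted phenyl to another. With compound 2 at the limit, compound 3 is expected to stay near it, the step of an at least 1.1-fold lower number from compound 2 to compound 3 (0.05 log units; that floor lies within the scatter) being estimated as none beyond the scatter. Compound 3 is estimated at 70000 nM, within a range from 30000 nM to 160000 nM, with a fair chance that this assay again reports only a limit.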

Compound 3, half-maximal inhibitory concentration: 14400 nM
Compound 3: middle estimate off by 4.9-fold (0.69 log units), on the high side; measured number outside the range, below it.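

In this assay the step of an at least 5.5-fold lower number from compound 2 to compound 3 (0.74 log units; beyond the scatter) is beyond the scatter, so the group on a saturated chain carbon bound to an amide-type nitrogen clearly affects the result, which the earlier step could not show because its floor lay within the scatter. The step of a 3.8-fold lower number from compound 1 to compound 3 (0.57 log units; beyond the scatter) is also beyond the scatter and rests on two measured numbers, so 3-azido-4-methoxyphenyl gives the lowest number of the three groups seen at this place. On these data alone, how large the gain over 3,4,5-trimethoxyphenyl really is remains unknown, because compound 2 gives only a limit and no number: the limit of > 80000 nM in this assay, at which 1 of the 3 values shown sits.

Compound 3 differs from both compound 1 and compound 2 by a whole substituted phenyl group, so these compounds cannot separate what the azido group contributes from what the methoxy group contributes. As far as these compounds go, it also remains open whether an amine or a nitrile in place of the azido group would give a similar number, or whether a phenyl carrying the azido group alone would do so.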